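The source may hold more compounds than are shown below. What is called first, only, known or untested is meant among the compounds shown, and "the series" means these compounds.

In a functional assay on MCF7 cells (Homo sapiens) for cytotoxicity, read by MTT assay, with a stated time of 72 h (on this read-out lower numbers stand for stronger inhibition and higher numbers for weaker inhibition), compound 3 `Fc1ccc(Nc2nc(SCc3ccc(C(F)(F)F)cc3)nc3ccccc23)cc1` gives 36300 nM, one of only two numbers shown. Compound 2 `FC(F)(F)c1ccc(CSc2nc(Nc3cccc(Cl)c3)c3ccccc3n2)cc1` gives 25100 nM, and the step of a 1.4-fold higher number from compound 2 to compound 3 (0.16 log units; within the scatter) is within the scatter. Compound 1 `FC(F)(F)c1ccc(CSc2nc(N3CCCCC3)c3ccccc3n2)cc1` reaches only the limit of > 50000 nM in this assay. Because of that limit, an at least 1.9-fold lower number from compound 1 to compound 2 (0.29 log units; that floor lies within the scatter) and an at least 1.3-fold lower number from compound 1 to compound 3 (0.13 log units; that floor lies within the scatter) are floors rather than measured sizes. Compound 4 `FC(F)(F)c1ccc(CSc2nc(Nc3ccc(Cl)cc3)c3ccccc3n2)cc1` differs from compound 3 by chloro in place of fluoro on an aromatic carbon. Among the measured compounds shown here, the one measured step touching this swap, a 1.4-fold higher number from compound 2 to compound 3 (0.16 log units; within the scatter), stayed within the scatter, though it exchanged 3-chlorophenyl for 4-fluorophenyl at the same time. A step of similar small size is therefore expected, leaning if anything toward a lower number. Compound 4 is estimated at 28000 nM, with a range from 12000 nM to 70000 nM. That expected step, a 1.3-fold lower number from compound 3 to compound 4 (0.11 log units; within the scatter), would lie within the scatter.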

Compound 4, half-maximal inhibitory concentration: 21500 nM
The estimate for compound 4 lay 1.3-fold (0.11 log units) above the measured number; the range from low to high includes it.
By their numbers in this assay, from the lowest: compounds 4, 2 and 3 (each within the scatter of the next). At a limit, above all of these: compound 1.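

In this assay, chloro in place of fluoro on this ring stays within the scatter, a 1.7-fold lower number from compound 3 to compound 4 (0.23 log units; within the scatter), and so does 4-chlorophenyl in place of 3-chlorophenyl, a 1.2-fold lower number from compound 2 to compound 4 (0.07 log units; within the scatter). Set against the piperidin-1-yl group, (4-chlorophenyl)amino gives the first step beyond the scatter, an at least 2.3-fold lower number from compound 1 to compound 4 (0.36 log units; beyond the scatter). That size is only a floor, because compound 1 stands at a limit: the limit of > 50000 nM in this assay, at which 1 of the 4 values shown sits.

Going by these compounds, how far the true gap to compound 1 extends remains open. So does whether a methoxy group or a nitrile in place of chloro would shift the number.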